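The source may hold more compounds than are shown below. What is called first, only, known or untested is meant among the compounds shown, and "the series" means these compounds.

Measured compounds:
- Compound 1, `CCCCCOc1nc(C(F)(F)F)ccc1CNC(=O)Nc1cccc2[nH]c(=O)ccc12`: 2.72 nM
- Compound 2, `CCCCCCOc1nc(C(F)(F)F)ccc1CNC(=O)Nc1cccc2[nH]c(=O)ccc12`: 3.19 nM
- Compound 3, `CC(C)COc1nc(C(F)(F)F)ccc1CNC(=O)Nc1cccc2[nH]c(=O)ccc12`: 2.6 nM

All three were measured in an assay on HEK cells for antagonist activity at transient receptor potential cation channel subfamily V member 1 (Homo sapiens), read by FLIPR (a lower number here means a stronger inhibitor, a higher number a weaker inhibitor), and the three share one core, differing only in the alkoxy group on the aromatic ring. Compound 3 sits within the scatter of both neighbours: the step of a 1.0-fold lower number from compound 1 to compound 3 (0.02 log units; within the scatter) and the step of a 1.2-fold lower number from compound 2 to compound 3 (0.09 log units; within the scatter) are both too small to count, as is a 1.2-fold higher number from compound 1 to compound 2 (0.07 log units; within the scatter) between the two straight chains. On these numbers compound 3 is indistinguishable from compound 1 and compound 2.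

Compound 4, `O=C(NCc1ccc(C(F)(F)F)nc1OCC1CCC1)Nc1cccc2[nH]c(=O)ccc12`, has not been measured. It differs from compound 3 by cyclobutyl in place of isopropyl on a saturated chain carbon bound to an oxygen on an aromatic ring. For the measured compounds named here, the steps that bear on this are the alkoxy variations among compounds 1, 2 and 3: branched or straight, shorter or longer, none of them moved the number beyond the scatter. Going by the values given here, a four-membered ring in place of the isopropyl is a further variation of the same alkoxy group, and no measured step gives grounds to expect a change beyond the scatter in this assay, in either direction. The step from compound 3 to compound 4 is therefore expected to be a 1.0-fold higher number from compound 3 to compound 4 (0.02 log units; within the scatter). Compound 4 is estimated at 2.7 nM, with a range from 1.3 nM to 5.5 nM.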

Compound 4, half-maximal inhibitory concentration: 1.49 nM
The estimate for compound 4 lay 1.8-fold (0.26 log units) above the measured number; the measured number falls inside the stated range.
By their numbers in this assay, from the lowest: compounds 4, 3, 1 and 2 (each within the scatter of the next, the first and the last beyond it).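

Working notes on the alkoxy position: in this assay, the one step at this place that clears the scatter is a 2.1-fold lower number from compound 2 to compound 4 (0.33 log units; beyond the scatter), with cyclobutyl in place of pentyl on a saturated chain carbon bound to an oxygen on an aromatic ring, and it is modest. The other two steps, a 1.7-fold lower number from compound 3 to compound 4 (0.24 log units; within the scatter) and a 1.8-fold lower number from compound 1 to compound 4 (0.26 log units; within the scatter), stay within the scatter, so the four-membered ring separates compound 4 from compound 2 but not from compound 3 or compound 1. This position therefore accepts a ring of carbon as well as straight and branched chains, with all four numbers in a narrow band, and nothing available bears on why cyclobutyl differs from pentyl here.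

Open, from the compounds shown here alone, is whether a cyclopropyl or cyclohexyl group at this place would stay within the scatter of compound 4 or leave it. Also open is what an amine, a hydroxyl or an ether oxygen on the alkoxy chain would do, since every group shown here is carbon only.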